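This account rests on a few compounds, and the source may have more. Where it says the series, first, only, none or still open, it means among the compounds named here.

Measured so far in an assay on L cells for inhibition of Protein-serine O-palmitoleoyltransferase porcupine (Mus musculus), read by reporter gene assay, with a stated time of 24 h; a lower number here means that less compound is needed, a higher number that more compound is needed for the effect:
- compound 2, `O=C(CNC(=O)c1nn(-c2ccccc2)c(=O)c2ccccc12)Nc1nc2ccc(Cl)cc2s1`: 30 nM
- compound 1, `O=C(CNC(=O)c1nn(-c2ccccc2)c(=O)c2ccccc12)Nc1nc2ccc([N+](=O)[O-])cc2s1`: 240 nM

Going by the values given here, compound 2 gives the lowest of the two numbers, with compound 1 the only neighbour, as an 8.0-fold lower number from compound 1 to compound 2 (0.90 log units; beyond the scatter) shows. Compound 3, `O=C(CNC(=O)c1nn(-c2ccccc2)c(=O)c2ccccc12)Nc1nccs1`, is not yet measured; it carries 1,3-thiazol-2-yl in place of 6-chloro-1,3-benzothiazol-2-yl on an amide-type nitrogen. Among the compounds with values here, no measured step covers this change directly; the single step from compound 1 to compound 2 only shows that the substituent on the outer ring of this group moves this assay. Loss of the whole fused ring and the chloro is therefore expected to raise the number, estimated at a 23-fold higher number from compound 2 to compound 3 (1.37 log units; beyond the scatter), giving compound 3 an expected 700 nM (120 nM to 5000 nM).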

Compound 3, half-maximal effective concentration: > 25000 nM
Compound 3: a limit, no number; the forecaster's own chance of this, stated with the estimate: 15%; middle value at least 35-fold (1.55 log units) away from the limit.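

In this assay, compound 3 gives no number, only a limit of the assay: the limit of > 25000 nM in this assay, at which 1 of the 3 values shown sits.

The change to 1,3-thiazol-2-yl on the amide-type nitrogen gives an at least 830-fold higher number from compound 2 to compound 3 (2.92 log units; beyond the scatter), and likewise an at least 100-fold higher number from compound 1 to compound 3 (2.01 log units; beyond the scatter). The earlier pair showed only that swapping the substituent moves the number; these steps show that losing the six-membered aromatic ring of carbon together with its substituent costs far more than that swap.

The compounds shown leave open how this loss divides between the ring and its substituent, a split that an unsubstituted 1,3-benzothiazol-2-yl on the same nitrogen would address.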